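Moving two fluorines in a series held at a limit

This account rests on a few compounds, and the source may have more. Where it says the series, first, only, none or still open, it means among the compounds named here.

In a toxicity assay on Vero cells (Chlorocebus sabaeus) for cytotoxicity (on this read-out higher numbers stand for lower toxicity in this test and lower numbers for higher toxicity in this test), compound 1 (`COc1nc(-c2ccccc2F)ccc1[C@@H](c1ccccc1)[C@@](O)(CCN(C)C)c1cccc2ccccc12`) gives > 50 ug/mL as a limit of the assay and not a number. Compound 2 (`COc1nc(-c2ccc(Br)cc2)ccc1[C@@H](c1ccccc1)[C@@](O)(CCN(C)C)c1cccc2ccccc12`) gives > 50 ug/mL as a limit too. Compound 3 (`COc1ncc(-c2ccccc2)cc1[C@@H](c1ccccc1)[C@@](O)(CCN(C)C)c1cc(F)cc(F)c1`) stands at > 50 ug/mL as well, again a limit and not a number.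

Compound 4 (`COc1ncc(-c2ccccc2)cc1[C@@H](c1ccccc1)[C@@](O)(CCN(C)C)c1cccc(F)c1F`) carries 2,3-difluorophenyl in place of 3,5-difluorophenyl on a saturated chain carbon bound to an oxygen on a saturated carbon and two saturated chain carbons with the same atoms joined differently.

Within the data shown here, the one measured step, a step that the two limits leave unreadable from compound 1 to compound 2 in this assay, has no readable size and changes a different group. Among the measured compounds shown here, the only guide is therefore the limit of > 50 ug/mL in this assay, at which 3 of the 3 values shown sit, so far. No step beyond the scatter is expected, and the estimated change is a step that the limit leaves unreadable from compound 3 to compound 4 in this assay with no clear direction. Compound 4 is estimated at 60 ug/mL with an expected range of 30 ug/mL to 120 ug/mL. Its result may well be only a limit.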

Compound 4, half-maximal cytotoxic concentration: > 50 ug/mL
Compound 4: no number, only a limit; the forecaster's own chance of this, stated with the estimate: 80%; the middle value lies beyond the limit too.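

In this assay compound 4 gives > 50 ug/mL, a limit of the assay and not a number. Among these compounds, compound 3 also stands at a limit, and no step from compound 3 to compound 4 can be read. The compounds shown leave open whether 2,3-difluorophenyl and 3,5-difluorophenyl differ at all on this read-out.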